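The compounds below may be only part of what the source reports. "The series", "measured", "known", "first", "only" and "open" are said of these compounds alone.

In an assay for displacement of a labelled ligand from Sigma non-opioid intracellular receptor 1 (Cavia porcellus) (on this read-out higher numbers stand for weaker inhibition and lower numbers for stronger inhibition), compound 1 `COC(=O)C1(c2ccc(C)cc2)CC1CN1CCN(c2ccccn2)CC1` gives 497 nM. Compound 2 `COC(=O)C1(c2ccc(N)cc2)CC1CN1CCN(c2ncccn2)CC1` gives > 10000 nM, which is a limit of the assay and not a number. Compound 2 thus stands at the limit of > 10000 nM in this assay, at which 1 of the 2 values shown sits. Compound 3 `COC(=O)C1(c2ccc(N)cc2)CC1CN1CCN(c2ccccn2)CC1` differs from compound 2 by pyridin-2-yl in place of pyrimidin-2-yl on an amine nitrogen in a ring. Going by the values given here, no measured step joins these two compounds. Compound 3 is expected to move toward stronger inhibition by an at least 3.3-fold lower number from compound 2 to compound 3 (0.52 log units; beyond the scatter), since compound 1 carrying the same pyridin-2-yl group gives 497 nM. Compound 3 is estimated at 3000 nM, within 800 nM to 12000 nM.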

Compound 3, inhibition constant: > 10000 nM
Compound 3: no number, only a limit (the forecaster's own chance of this, stated with the estimate: 35%); middle value at least 3.3-fold (0.52 log units) away from the limit.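

In this assay compound 3 gives > 10000 nM, which is a limit of the assay and not a number, as for compound 2, so the step between pyrimidin-2-yl and pyridin-2-yl cannot be read. With pyridin-2-yl kept, amino in place of methyl on an aromatic carbon gives an at least 20-fold higher number from compound 1 to compound 3 (1.30 log units; beyond the scatter), so pyridin-2-yl alone does not hold the number near that of compound 1. Both amino compounds sit at the limit: the limit of > 10000 nM in this assay, at which 2 of the 3 values shown sit.

Open, on these data alone, is whether pyrimidin-2-yl changes anything when methyl stands on the aromatic carbon. Also open, as far as these compounds go, is whether a hydroxyl or a chlorine in place of amino would bring the number back toward that of compound 1.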